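The source may hold more compounds than are shown below. What is called first, only, known or untested is meant among the compounds shown, and "the series" means these compounds.

Measured so far in a functional assay on NALM-6 cells (Homo sapiens); on this read-out higher numbers stand for weaker inhibition and lower numbers for stronger inhibition:
- compound 1 `CCCCSC[C@H](NC(C)=O)C(=O)CCl` gives 41400 nM
- compound 2 `CCCCCSC[C@H](NC(C)=O)C(=O)CCl` gives 5800 nM

For the measured compounds named here, compound 2 holds the lower of the two numbers in this assay; the only comparison available is a 7.1-fold lower number from compound 1 to compound 2 (0.85 log units; beyond the scatter). Compound 3 `CCCCCCCCSC[C@H](NC(C)=O)C(=O)CCl` lengthens the same chain further: propyl in place of hydrogen on a saturated chain carbon, five bonds along the chain from a sulfur. Going by the values given here, the one measured step that bears on this, a 7.1-fold lower number from compound 1 to compound 2 (0.85 log units; beyond the scatter), put methyl in place of hydrogen on that chain and lowered the number clearly. A longer extension may continue in that direction, though with a single step known the size is uncertain. For compound 3 a further drop is expected, a 3.9-fold lower number from compound 2 to compound 3 (0.59 log units; beyond the scatter), giving an estimated 1500 nM with a range from 400 nM to 6000 nM.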

Compound 3, half-maximal inhibitory concentration: 5600 nM
Compound 3: the middle estimate sits 3.7-fold (0.57 log units) below what was measured; the range from low to high includes it.
By their numbers in this assay, from the lowest: compounds 3 and 2 (each within the scatter of the next); then compound 1.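

In this assay the earlier gain from lengthening the chain does not carry on at this place: propyl in place of hydrogen gives a 1.0-fold lower number from compound 2 to compound 3 (0.02 log units; within the scatter) and so no real change. The longer chain still holds the gain over the shortest one, with a 7.4-fold lower number from compound 1 to compound 3 (0.87 log units; beyond the scatter) as the overall step, so these compounds show a drop followed by a flat stretch rather than a steady fall. The compounds shown leave open whether a still longer chain, or a chain ending in an amine or a carboxylic acid, would stay flat or move the number again. No supporting data are available to explain this flattening.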